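A few compounds are considered here, and "the series" means these few. Any claim that something is new, unique, unknown or untested is made for them only; others in the source may bear on it.

Measured compounds:
compound 1 `N#Cc1c(O)nc(SCc2nc3ccccc3[nH]2)nc1-c1ccccc1` — 2.55 nM
compound 2 `N#Cc1c(Nc2nccs2)nc(SCc2nc3ccccc3[nH]2)nc1-c1ccccc1` — 11.9 nM

Both numbers come from a functional assay on HL-60 cells (Homo sapiens) for cytotoxicity, read by MTT assay, with a stated time of 3 days; a lower number here means a stronger inhibitor, a higher number a weaker inhibitor. For the measured compounds named here, compound 1 holds the lowest number of the two; the nearest measured neighbour is compound 2, and the one recorded step, a 4.7-fold higher number from compound 1 to compound 2 (0.67 log units; beyond the scatter), is the only comparison available in this assay.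

The unmeasured compound is compound 3 `N#Cc1c(NC(N)=S)nc(SCc2nc3ccccc3[nH]2)nc1-c1ccccc1`. Against compound 1 the change is a group of 4 heavy atoms (1 carbon, 2 nitrogen, 1 sulfur; no ring) in place of one oxygen atom, on an aromatic carbon.

Going by the values given here, the step that bears on it is the one from compound 1 to compound 2, where the same hydroxy was exchanged for (1,3-thiazol-2-yl)amino at the same aromatic carbon and the number rose modestly, beyond the scatter. The entering group of compound 3 is a different one, so that step is a guide to the kind of change, not to its exact size. The expectation for compound 3 is therefore a higher number than compound 1 in this assay, with the step of a 3.1-fold higher number from compound 1 to compound 3 (0.50 log units; beyond the scatter) taken as a modest one, and with the possibility that the result stays within the scatter of compound 1 left open.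

For compound 3 the estimated value in this assay is 8 nM, with a range from 2.5 nM to 30 nM.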

Compound 3, half-maximal inhibitory concentration: 5.81 nM
Estimate against measurement, compound 3: 1.4-fold (0.14 log units) above; the measured number falls inside the stated range.
By their numbers in this assay, from the lowest: compound 1; then compound 3; then compound 2.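

In this assay, the second replacement at this aromatic carbon gives a 2.3-fold higher number from compound 1 to compound 3 (0.36 log units; beyond the scatter), so two quite different nitrogen-linked groups now both stand above the hydroxy of compound 1, each by a step beyond the scatter. The size of the rise depends on the entering group: on the nitrogen attached to the aromatic ring, the open group without a ring in place of the (1,3-thiazol-2-yl) ring gives a 2.0-fold lower number from compound 2 to compound 3 (0.31 log units; beyond the scatter), which places compound 3 between the other two compounds. Nothing shown here accounts for either step.

For the compounds shown here, with only three groups at this carbon, it remains open whether the higher numbers go with the nitrogen link in general or with the two particular groups attached to it. A plain amine or a methoxy group on the same aromatic carbon, set beside compound 1 and compound 3, would help separate those readings, and an acetamide would test whether the sulfur of compound 3 matters to its number.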